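One Five-Membered Aromatic Ring Exchanged for Another

The compounds below may be only part of what the source reports. "The series", "measured", "known", "first", "only" and "open" are said of these compounds alone.

In an ADME assay on the whole organism (strain 129/SvEvBrd x C57BL/6) for metabolic stability, with Mus musculus as the target (on this read-out higher numbers stand for a longer-lived compound and lower numbers for a shorter-lived compound), compound 1 `CC(=O)c1nc([C@@H](O)[C@H](O)[C@H](O)CO)cn1C` gives 2.4 h and compound 2 `OC[C@@H](O)[C@@H](O)[C@H](O)c1c[nH]c(-c2cscn2)n1` gives 4.2 h. These two numbers lie within the scatter of each other, so compound 2 cannot be separated from compound 1 on this evidence. Compound 3 `OC[C@@H](O)[C@@H](O)[C@H](O)c1c[nH]c(-c2ncon2)n1` has 1,2,4-oxadiazol-3-yl in place of the 1,3-thiazol-4-yl of compound 2, on an aromatic carbon of a five-membered aromatic ring with 2 nitrogen. The counted change is 1,2,4-oxadiazol-3-yl in place of 1,3-thiazol-4-yl on an aromatic carbon. For the measured compounds named here, no measured pair differs in one place only, so the data give no direct guide to this exchange. In this assay, no step beyond the scatter is therefore expected. The expected move is a 1.4-fold lower number from compound 2 to compound 3 (0.15 log units; within the scatter). For compound 3 the estimate is 3 h, with an expected range from 1.2 h to 7 h.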

Compound 3, half-life: 0.7 h
Estimate against measurement, compound 3: 4.3-fold (0.63 log units) above; measured number below the stated range.
By their numbers in this assay, from the lowest: compound 3; then compounds 1 and 2 (each within the scatter of the next).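

For the compounds shown here, this exchange gives the first pair in the set that differs in one place only, and in this assay it reads as a 6.0-fold lower number from compound 2 to compound 3 (0.78 log units; beyond the scatter), a step that stands clear of the scatter. On an aromatic carbon of a five-membered aromatic ring with 2 nitrogen, between two ring nitrogen atoms, the read-out therefore tells one five-membered aromatic ring from another, with 1,2,4-oxadiazol-3-yl giving the shorter-lived compound of this pair. No measured property in the material bears on the origin of this step.

A single exchange leaves open whether the step belongs to the ring as a whole or to one of its atoms. As far as these compounds go, how a pyridyl ring, a primary amide or an amine would read at this place also remains open.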